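Replacing the Chain of Compound 3

A few compounds are considered here, and "the series" means these few. Any claim that something is new, unique, unknown or untested is made for them only; others in the source may bear on it.

Four compounds share one core and differ in the chain on its oxygen. In a functional assay on U-937 cells (Homo sapiens) for inhibition, read by MTT assay, with a stated time of 48 h (on this read-out higher numbers stand for weaker inhibition and lower numbers for stronger inhibition), compound 1 `O=S(=O)(c1ccccc1)c1c(OCCCCCCO)no[n+]1[O-]` stands as "not determined" (no result reported) and gives no number. In this assay compound 2 `O=C(CCCOc1no[n+]([O-])c1S(=O)(=O)c1ccccc1)NO` gives 3300 nM and compound 3 `O=C(COCCOc1no[n+]([O-])c1S(=O)(=O)c1ccccc1)NO` gives 8150 nM as its value. Compound 3 thus holds the higher of the two numbers, and compound 2 lies below it by a margin beyond the scatter.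

Compound 4 `CC(C)(COc1no[n+]([O-])c1S(=O)(=O)c1ccccc1)C(=O)NO` has not yet been measured. Its difference from compound 3 is 1-(hydroxycarbamoyl)-1-methylethyl in place of ((hydroxycarbamoyl)methoxy)methyl on a saturated chain carbon bound to an oxygen on an aromatic ring and reads in words as 1-(hydroxycarbamoyl)-1-methylethyl in place of ((hydroxycarbamoyl)methoxy)methyl on a saturated chain carbon bound to an oxygen on an aromatic ring. Among the measured compounds shown here, the one measured step that bears on this is a 2.5-fold higher number from compound 2 to compound 3 (0.39 log units; beyond the scatter) and it is modest: it put (hydroxycarbamoyl)methoxy in place of (hydroxycarbamoyl)methyl. For the measured compounds named here, the group entering compound 4 holds no such methoxy link, so part of that step may be given back, yet no measured compound carries its branched methyl groups. In this assay a small move toward a lower number is therefore expected, one that may stay inside the scatter. The expected step runs as a 1.4-fold lower number from compound 3 to compound 4 (0.13 log units; within the scatter) and no larger one is foreseen. Compound 4 is estimated at 6000 nM within a range of 2000 nM to 18000 nM for this read-out.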

Compound 4, half-maximal inhibitory concentration: 12500 nM
The estimate for compound 4 lay 2.1-fold (0.32 log units) below the measured number; the range from low to high includes it.
By their numbers in this assay, from the lowest: compound 2; then compounds 3 and 4 (each within the scatter of the next).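

With the new number, taking the chain oxygen out of the group does not by itself restore the lower number of compound 2: the 1-(hydroxycarbamoyl)-1-methylethyl group of compound 4 and the ((hydroxycarbamoyl)methoxy)methyl group of compound 3 cannot be told apart in this assay, where the result is a 1.5-fold higher number from compound 3 to compound 4 (0.19 log units; within the scatter) and the two stand level. The 2-(hydroxycarbamoyl)ethyl group keeps its place against the branched group as well, with a 3.8-fold higher number from compound 2 to compound 4 (0.58 log units; beyond the scatter), so at this position compound 2 now holds the lowest number, beyond the scatter of both other compounds, and neither replacement goes against that among these three. Nothing available explains these differences.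

Going by these compounds, whether a single methyl group on the same chain carbon would stay near compound 2 or move toward compound 4 remains open, so the part played by each of the two branching methyl groups cannot be separated. Also open, on these data alone, is how a longer chain ending in hydroxycarbamoyl, or a carboxylic acid in place of the hydroxycarbamoyl group, would read on this assay.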